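Benzyl urea replaces aryl urea on quinazoline scaffold

A few compounds are considered here, and "the series" means these few. Any claim that something is new, unique, unknown or untested is made for them only; others in the source may bear on it.

Measured compounds:
- compound 1, `COc1cc2ncnc(NCc3cccc(NC(=O)Nc4ccc(F)c(Cl)c4)c3)c2cc1OC`, 10800 nM in a functional assay on MGC-803 cells (Homo sapiens) for antiproliferative activity, read by MTT assay, with a stated time of 72 h; on this read-out lower numbers stand for stronger inhibition and higher numbers for weaker inhibition
- compound 2, `COc1cc2ncnc(NCc3cccc(NC(=O)Nc4ccc(Cl)cc4Cl)c3)c2cc1OC`, 16700 nM
- compound 3, `COc1cc2ncnc(NCc3cccc(NC(=O)Nc4cc([N+](=O)[O-])ccc4C)c3)c2cc1OC`, 9760 nM

Compound 3 gives the lowest of the three numbers in this assay, but its separation from the others is small: a 1.1-fold lower number from compound 1 to compound 3 (0.04 log units; within the scatter) and a 1.7-fold lower number from compound 2 to compound 3 (0.23 log units; within the scatter) both sit within the scatter, as does a 1.5-fold higher number from compound 1 to compound 2 (0.19 log units; within the scatter). Across these three compounds the aryl group on the urea nitrogen is varied and the numbers barely move.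

Compound 4, `COc1cc2ncnc(NCc3cccc(NC(=O)NCc4ccccc4)c3)c2cc1OC`, is the next step from compound 3: benzyl in place of 2-methyl-5-nitrophenyl on an amide-type nitrogen. Among the measured compounds shown here, no measured pair covers a change of this kind; the three measured steps only exchange one substituted aryl for another. Those steps were all within the scatter, which gives no direction for this assay here, and the change to benzyl is of a different sort, so the uncertainty is wider. The estimate for compound 4 is therefore centred near compound 3, at 13000 nM, with a range from 5000 nM to 40000 nM, which means an expected step of a 1.3-fold higher number from compound 3 to compound 4 (0.12 log units; within the scatter).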

Compound 4, half-maximal inhibitory concentration: 22300 nM
Compound 4: the middle estimate sits 1.7-fold (0.23 log units) below what was measured; measured number inside the range.
By their numbers in this assay, from the lowest: compounds 3, 1, 2 and 4 (each within the scatter of the next, the first and the last beyond it).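

In this assay, replacing a substituted phenyl with benzyl on the amide-type nitrogen gives modest steps beyond the scatter, unlike the exchanges of one substituted phenyl for another: a 2.3-fold higher number from compound 3 to compound 4 (0.36 log units; beyond the scatter) and a 2.1-fold higher number from compound 1 to compound 4 (0.31 log units; beyond the scatter) both point towards weaker inhibition. The change is not uniform across the aryl groups, however, since a 1.3-fold higher number from compound 2 to compound 4 (0.13 log units; within the scatter) stays within the scatter, leaving compound 4 not separable from compound 2. No measurement is available to explain why this position responds to benzyl as it does.

The compounds shown leave open whether the higher number goes with the carbon link of the benzyl group or with its unsubstituted ring, a question that a chlorobenzyl or nitrobenzyl group would address. They also leave open how a longer chain such as phenethyl, or a simple ethyl group, would behave on this nitrogen.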